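The compounds below may be only part of what the source reports. "The series", "measured", "known", "first", "only" and "open" are said of these compounds alone.

Working notes on the series.

Compound 1 `CC[C@@H](Nc1c(C#N)c(-c2ccc(-c3cccc(C)c3F)cc2)nc2cnccc12)C(N)=O` is the reference point. In a physicochemical assay for lipophilicity, read by HPLC, at pH 7.5 (a lower number here means a more polar compound, a higher number a more lipophilic compound), compound 1 gives 3 and stands highest of the three numbers in hand. Compound 2 `CCOc1ccccc1-c1ccc(-c2nc3cnccc3c(N[C@H](CC)C(=O)NS(=O)(=O)C3CC3)c2C#N)cc1` gives in this assay a value of 2.3 which lies below compound 1 by a gap beyond the scatter. Compound 3 `CN(CC(N)=O)c1c(C#N)c(-c2ccc(Br)cc2)nc2cnccc12` gives in this assay a value of 2.1 and is furthest from compound 1, again beyond the scatter. For the measured compounds named here, compounds 2 and 3 differ from compound 1 in more than one place, so no single step between measured compounds can be read off.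

Compound 4 `CC[C@@H](Nc1c(C#N)c(-c2ccc(-c3ccccc3Cl)cc2)nc2cnccc12)C(N)=O` is not yet measured. It differs from compound 1 in one place only, namely 2-chlorophenyl in place of 2-fluoro-3-methylphenyl on an aromatic carbon and nothing else. Going by the values given here, no pair among the measured compounds isolates an exchange of this kind, so the expectation rests on the structural change alone. The step from compound 1 to compound 4 is expected to be small, a number 0.10 log units lower from compound 1 to compound 4 (within the scatter) in size, within the usual scatter and in no clear direction. Compound 4 is accordingly estimated to give about 2.9 in this assay with a range from 2.5 to 3.3 in the same units.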

Compound 4, distribution coefficient: 2.9
Compound 4: middle estimate and measured number agree at the digits printed, within the range that was stated.
By their numbers in this assay, from the lowest: compounds 3 and 2 (each within the scatter of the next); then compounds 4 and 1 (each within the scatter of the next).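

For the compounds shown here, the exchange gives a number 0.10 log units lower from compound 1 to compound 4 (within the scatter), the first step that can be read at a single place: in this assay, 2-chlorophenyl stands in for 2-fluoro-3-methylphenyl on this aromatic carbon, para to a large group, with no change beyond the scatter. Both groups are six-membered aromatic rings of carbon only, with no hydrogen-bond donors or acceptors and no net charge, and this one exchange does not separate them. Nothing measured bears on why the two groups read alike.

Still open, as far as these compounds go, is how a pyridyl ring, or a phenyl ring carrying an amine or a carboxylic acid, would read at this position. Steps to compounds 2 and 3 cannot be read, so whether this exchange would read the same with their different side chains also stays open.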